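The source may hold more compounds than are shown below. What is called first, only, known or untested is meant among the compounds shown, and "the series" means these compounds.

Measured compounds:
compound 1 `C[C@@H](c1nnc(-c2ccc(Cl)cc2)o1)[C@H]1CC[C@@H](c2ccnc3ccc(F)cc32)CC1` with 41%
compound 2 `C[C@@H](c1nc2cc(F)ccc2[nH]1)[C@H]1CC[C@@H](c2ccnc3ccc(F)cc32)CC1` with 5%

Both compounds were tested in an ADME assay on microsomes from liver (Mus musculus) for metabolic stability, with a stated time of 10 min, tested at 0.5 uM; a lower number here means that less of the compound is left, a higher number that more of the compound is left. Compound 1 gives 41%, which is the higher of the two numbers. Compound 2 gives 5%, a result that lies well beyond the scatter below compound 1, so compound 1 stands clearly at the top of what has been measured. Among the compounds with values here, the two compounds share the same core and differ only in the aromatic ring that carries the methyl-bearing carbon, and no computed step between them has been determined.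

The next compound, compound 3 `COc1ccc(Nc2nnc([C@H](C)[C@H]3CC[C@@H](c4ccnc5ccc(F)cc54)CC3)o2)cc1`, is derived from compound 1 by a single change: (4-methoxyphenyl)amino in place of 4-chlorophenyl on an aromatic carbon. Within the data shown here, there is no measured pair that isolates this change. The expected step is estimated as a number 21 percentage points lower from compound 1 to compound 3 (beyond the scatter), a downward step beyond the scatter. For compound 3 the expected value is 20%, with a range from 5% to 40%.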

Compound 3, percent of the compound remaining: 2%
Compound 3: middle estimate off by 18 percentage points, on the high side; measured number below the stated range.
By their numbers in this assay, from the lowest: compounds 3 and 2 (each within the scatter of the next); then compound 1.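

In this assay, the aromatic carbon of the five-membered aromatic ring with 2 nitrogen and 1 oxygen proves a sensitive place: (4-methoxyphenyl)amino in place of 4-chlorophenyl gives a number 39 percentage points lower from compound 1 to compound 3 (beyond the scatter). Within the data shown here, the core stays the same in this pair, so this large step belongs to the exchange at this one place, although the exchange brings in the amino nitrogen and the methoxy oxygen together, and the single step cannot separate them. Nothing measured here accounts for the step.

Open, as far as these compounds go, is whether a (4-chlorophenyl)amino group or a 4-methoxyphenyl group on that carbon would stay close to compound 1 or fall as far as compound 3. Equally open, from the compounds shown here alone, is how a small group there, such as a methyl or an amine, would fare.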